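The source may report more compounds than this note shows. Statements on the series, on what has been measured and on what is new or still open speak of the compounds shown alone.

Values measured in a functional assay on SK-BR-3 cells (Homo sapiens) for antiproliferative activity, read by MTT assay, with a stated time of 72 h (a higher number here means a weaker inhibitor, a lower number a stronger inhibitor), follow
- Compound 1 `C/C=C1/[C@H](O[C@@H]2O[C@H](CO)[C@@H](O)[C@H](O)[C@H]2O)OC=C(C(=O)OC)[C@H]1CC(=O)OCc1ccc2c(c1)OCCO2` gives > 15000 nM
- Compound 2 `C/C=C1/[C@H](O[C@@H]2O[C@H](CO)[C@@H](O)[C@H](O)[C@H]2O)OC=C(C(=O)OC)[C@H]1CC(=O)OCC` gives > 15000 nM
- Compound 3 `C/C=C1/[C@H](O[C@@H]2O[C@H](CO)[C@@H](O)[C@H](O)[C@H]2O)OC=C(C(=O)OC)[C@H]1CC(=O)OCc1ccc(OC)c(OC)c1` gives > 15000 nM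

Each of these values is a limit of the assay and not a number. Compound 3 therefore has no rank among the others, as the evidence shows: the limit of > 15000 nM in this assay, at which 3 of the 3 values shown sit. In compound 4 `C/C=C1/[C@H](O[C@@H]2O[C@H](CO)[C@@H](O)[C@H](O)[C@H]2O)OC=C(C(=O)OC)[C@H]1CC(=O)OCCc1ccc(O)c(O)c1`, 3,4-dihydroxybenzyl takes the place of 3,4-dimethoxyphenyl on a saturated chain carbon bound to an oxygen next to a carbonyl group (3,4-dihydroxybenzyl in place of 3,4-dimethoxyphenyl on a saturated chain carbon bound to an oxygen next to a carbonyl group). The measured changes at this place are a step that the two limits leave unreadable from compound 1 to compound 3 and a step that the two limits leave unreadable from compound 2 to compound 3, along with a step that the two limits leave unreadable from compound 1 to compound 2. None gives a size, so no change beyond the scatter is expected, and another limit is likely. The expected change is a step that the limit leaves unreadable from compound 3 to compound 4. The estimate for compound 4 is 20000 nM, with an expected range from 8000 nM to 60000 nM.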

Compound 4, half-maximal inhibitory concentration: 160000 nM
Beside the measured number, compound 4's estimate is 8.0-fold (0.90 log units) below it, outside the stated range (above it).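

No step to compound 4 can be read from compound 1, compound 2 or compound 3, since each of those three stands at a limit of the assay, not a number: the limit of > 15000 nM in this assay, at which 3 of the 4 values shown sit.

From the compounds shown here alone, how these four compounds truly rank in this assay stays open.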